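From 4-methylphenoxy to 4-fluorophenoxy: notes on the series

The source may report more compounds than this note shows. Statements on the series, on what has been measured and on what is new or still open speak of the compounds shown alone.

Measured in a functional assay on A549 cells (Homo sapiens) for antiproliferative activity, read by MTT assay, with a stated time of 48 h; a lower number here means a stronger inhibitor, a higher number a weaker inhibitor:
- compound 1 `Cc1ccc(Oc2nc3ccccc3cc2/C=N/NC(=O)Cn2c([N+](=O)[O-])cnc2C)cc1`: 21500 nM
- compound 2 `Cc1ccc2nc(Oc3ccccc3)c(/C=N/NC(=O)Cn3c([N+](=O)[O-])cnc3C)cc2c1`: 7180 nM
- compound 3 `Cc1ccc(Oc2nc3ccc(C)cc3cc2/C=N/NC(=O)Cn2c([N+](=O)[O-])cnc2C)cc1`: 1190 nM

Compound 3 has the lowest number of the three, and both of its measured steps lie beyond the scatter. The next change leads to compound 4 `Cc1ccc2nc(Oc3ccc(F)cc3)c(/C=N/NC(=O)Cn3c([N+](=O)[O-])cnc3C)cc2c1`, with fluoro in place of methyl on an aromatic carbon, para to a large group, so that 4-methylphenoxy becomes 4-fluorophenoxy (fluoro in place of methyl on an aromatic carbon).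

Two measured steps involve a methyl group. The closer one is a 6.0-fold lower number from compound 2 to compound 3 (0.78 log units; beyond the scatter), since it creates the same 4-methylphenoxy group that is changed here. The other, an 18-fold lower number from compound 1 to compound 3 (1.26 log units; beyond the scatter), places a methyl on the shared core and so bears on this change only indirectly. The series holds no measured fluoro compound, so the effect of fluoro is not directly shown.

Removing the methyl could give back part of the gain seen on going from compound 2 at 7180 nM to compound 3 at 1190 nM, while fluoro need not behave like hydrogen. A modest rise is therefore expected in this assay, partly offsetting that step. The expected step is a 2.4-fold higher number from compound 3 to compound 4 (0.37 log units; beyond the scatter). The estimate for compound 4 is 2800 nM, with an expected range from 900 nM to 8000 nM.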

Compound 4, half-maximal inhibitory concentration: 190 nM
Compound 4: middle estimate off by 15-fold (1.17 log units), on the high side; the measured number lies below the stated range.
By their numbers in this assay, from the lowest: compound 4; then compound 3; then compound 2; then compound 1.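

In this assay, 4-fluorophenoxy does not give back the gain made with 4-methylphenoxy, as the working estimate supposed: the change runs the other way, with a 6.3-fold lower number from compound 3 to compound 4 (0.80 log units; beyond the scatter), so the methyl group is not required for a low number at this position. Measured against the hydrogen of compound 2, fluoro gives a 38-fold lower number from compound 2 to compound 4 (1.58 log units; beyond the scatter), while methyl gives a 6.0-fold lower number from compound 2 to compound 3 (0.78 log units; beyond the scatter); among these three compounds, both groups lower the number relative to hydrogen, and the order at this position is fluoro, then methyl, then hydrogen. Nothing available bears on why fluoro and methyl differ here.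

Still open, on these data alone, is whether chloro, methoxy or trifluoromethyl in the same place would fall nearer to fluoro or to methyl, which would show how far the fluoro result is particular to that atom. Also open, as far as these compounds go, is whether the fluoro gain holds on the shared core without its methyl group, the form in which compound 1 gives 21500 nM, since all the fluoro evidence here comes from a single compound.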